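This account rests on a few compounds, and the source may have more. Where it says the series, first, only, none or still open, it means among the compounds named here.

Compound 2 `N#Cc1c(Cn2c(=O)n(C3CC3)c3ccncc32)nc2cc(Cl)ccn12` holds the only number shown in an ADME assay on HEp-2 cells (Homo sapiens) for cytotoxicity, read by CCK-8 assay, with a stated time of 6 days (on this read-out higher numbers stand for lower toxicity in this test and lower numbers for higher toxicity in this test), at 22500 nM. Compound 1 `O=c1n(Cc2nc3cc(Cl)ccn3c2CCCCO)c2cnccc2n1C1CC1` gives only a limit in this assay, > 100000 nM. Going by the values given here, the single measured step, an at least 4.4-fold lower number from compound 1 to compound 2 (0.64 log units; beyond the scatter), rests on that limit: the limit of > 100000 nM in this assay, at which 1 of the 2 values shown sits. Compound 3 `O=c1n(Cc2nc3cc(Cl)ccn3c2CO)c2cnccc2n1C1CC1` moves back toward compound 1 by hydroxymethyl in place of cyano on an aromatic carbon. Because an at least 4.4-fold lower number from compound 1 to compound 2 (0.64 log units; beyond the scatter) went with the loss of 4-hydroxybutyl, restoring a hydroxyalkyl group in compound 3 is expected to carry the number back up, as a 3.6-fold higher number from compound 2 to compound 3 (0.55 log units; beyond the scatter). Compound 3 is therefore expected near 80000 nM, within 25000 nM to 300000 nM, with a fair chance that this assay again reports only a limit.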

Compound 3, half-maximal cytotoxic concentration: > 100000 nM
Compound 3 was reported as a limit (the forecaster's own chance of this, stated with the estimate: 45%); middle value at least 1.2-fold (0.09 log units) away from the limit.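

Hydroxymethyl in place of cyano on this aromatic carbon gives an at least 4.4-fold higher number from compound 2 to compound 3 (0.64 log units; beyond the scatter), so the lower number in this assay now follows cyano from both sides, with 4-hydroxybutyl and with the much shorter hydroxymethyl. The step between compound 1 and compound 3 cannot be read, and any effect of chain length stays hidden: the limit of > 100000 nM in this assay, at which 2 of the 3 values shown sit.

Still open, from the compounds shown here alone, is whether the lower number is particular to the nitrile, or whether an amine or a carboxylic acid on this carbon would also bring it down. Going by these compounds, how far compound 1 and compound 3 lie past the limit also remains unknown.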